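The source may report more compounds than this note shows. Statements on the series, on what has been measured and on what is new or still open speak of the compounds shown alone.

Series notes, arylsulfonyl set in an assay on isolated protein for displacement of a labelled ligand from metabotropic glutamate receptor 5 (Homo sapiens), with a stated time of 60 min, tested at 1 uM; a higher number here means more inhibition at the concentration tested (going by the name of the read-out), a lower number less inhibition.

Compound 3 `COc1cccc(S(=O)(=O)c2cnc3ccc(OC)cc3c2N2CCC(C)CC2)c1` gives 0% in this assay, the lowest of the three numbers measured. Compound 2 `COc1ccc2ncc(S(=O)(=O)c3ccc(F)cc3)c(N3CCC(C)CC3)c2c1` gives 27%, and compound 1 `COc1ccc(S(=O)(=O)c2cnc3ccc(OC)cc3c2N2CCC(C)CC2)cc1` gives 41%. Both steps down to compound 3 are beyond the scatter: a number 41 percentage points lower from compound 1 to compound 3 (beyond the scatter), and a number 27 percentage points lower from compound 2 to compound 3 (beyond the scatter).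

Compound 4 `COc1ccc2ncc(S(=O)(=O)c3cccc(F)c3)c(N3CCC(C)CC3)c2c1` differs from compound 3 by fluoro in place of methoxy on an aromatic carbon. Within the data shown here, the one measured step that bears on this change is the swap on the other aryl sulfone, a number 14 percentage points lower from compound 1 to compound 2 (beyond the scatter), where the loss was modest. Compound 3 already sits at the floor of the read-out, so a further drop of that size cannot show; a gain is not indicated by any measured step. The expectation for compound 4 is therefore a step of a number 3 percentage points higher from compound 3 to compound 4 (within the scatter), within the scatter. Compound 4 is estimated at 3% in this assay, with a range from 0% to 15%.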

Compound 4, a percentage reported as inhibition, at one concentration (the size of the read-out at that concentration, not a potency): 68%
For compound 4 the middle estimate is 65 percentage points below the measured one; the measured number lies above the stated range.
By their numbers in this assay, from the lowest: compound 3; then compound 2; then compound 1; then compound 4.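

From 3-methoxyphenyl to 3-fluorophenyl, this assay gives a number 68 percentage points higher from compound 3 to compound 4 (beyond the scatter) and the change from 4-methoxyphenyl to 4-fluorophenyl runs the other way, so fluoro in place of methoxy has no single direction across these two aryl sulfones: the same change on two cores in this assay, a number 14 percentage points lower (beyond the scatter) from compound 1 to compound 2 and a number 68 percentage points higher (beyond the scatter) from compound 3 to compound 4, 82 percentage points apart, beyond the scatter of two such steps. With 3-fluorophenyl in place of 4-fluorophenyl the result is a number 41 percentage points higher from compound 2 to compound 4 (beyond the scatter) while 3-methoxyphenyl in place of 4-methoxyphenyl gave a number 41 percentage points lower from compound 1 to compound 3 (beyond the scatter) and the better placement on this ring therefore changes with the group carried. With 3-fluorophenyl in place of 4-methoxyphenyl the result is a number 27 percentage points higher from compound 1 to compound 4 (beyond the scatter) and this leaves compound 4 highest of the four, with all its steps beyond the scatter.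

These percentages at one concentration give no potency. As far as these compounds go, whether chloro, nitrile or hydroxy on the same ring carbon would follow fluoro or methoxy stays open.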